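Lengthening the linker between a cyanoguanidine core and chlorophenoxy group

The compounds below may be only part of what the source reports. "The series", "measured", "known", "first", "only" and "open" are said of these compounds alone.

Three compounds share a core: compound 1 `CCC1C(=O)N(CCCCCCOc2ccc(Cl)cc2)/C(=N\C#N)N1c1ccncc1`, compound 2 `N#C/N=C1\N(CCCCCOc2ccc(Cl)cc2)C(=O)C(c2ccccc2)N1c1ccncc1` and compound 3 `N#C/N=C1\N(CCCCCOc2ccc(Cl)cc2)C(=O)CCN1c1ccncc1`. In a functional assay on MCF7 cells (Homo sapiens) for cytotoxicity (a higher number here means a weaker inhibitor, a lower number a stronger inhibitor), compound 1 gives 6910 nM, compound 2 gives 1000 nM and compound 3 gives 5460 nM. Compound 3 thus holds the second highest of the three numbers; its nearest neighbour is compound 1, within the scatter, while compound 2 lies beyond the scatter below it. Compound 4 `N#C/N=C1\N(CCCCCCOc2ccc(Cl)cc2)C(=O)CCN1c1ccncc1` differs from compound 3 by (4-chlorophenoxy)methyl in place of 4-chlorophenoxy on a saturated chain carbon, five bonds along the chain from an amide-type nitrogen in a ring. Among the compounds with values here, no measured pair isolates this change, and compound 1, which carries the longer chain together with a further substituent, is within the scatter of compound 3. The step of a 1.1-fold higher number from compound 3 to compound 4 (0.04 log units; within the scatter) is therefore expected to stay within the scatter. Compound 4 is estimated at 6000 nM, between 2500 nM and 14000 nM.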

Compound 4, half-maximal inhibitory concentration: 454 nM
Estimate against measurement, compound 4: 13-fold (1.12 log units) above; the measured number lies below the stated range.
By their numbers in this assay, from the lowest: compound 4; then compound 2; then compounds 3 and 1 (each within the scatter of the next).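

In this assay, (4-chlorophenoxy)methyl in place of 4-chlorophenoxy, on a saturated chain carbon five bonds along the chain from an amide-type nitrogen in a ring, gives a 12-fold lower number from compound 3 to compound 4 (1.08 log units; beyond the scatter). Within the data shown here, this position therefore responds strongly to this one change, which the earlier compounds could not show. With the chain of compound 4 and a further substituent, compound 1 gives 6910 nM, so this chain does not bring a low number in every compound. Nothing measured here explains the step. Going by these compounds, whether a still longer chain keeps the low number, and whether an amine in the chain in place of the phenoxy oxygen does so, remains open.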